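The compounds below may be only part of what the source reports. "The series", "measured", "known", "first", "only" and "open" are said of these compounds alone.

Compound 1 `CCCn1cnc2ncnc(N)c21` carries a plain alkyl chain on the shared core. In an assay on CHO cells for displacement of a labelled ligand from adenosine receptor A1 (Homo sapiens) (on this read-out higher numbers stand for weaker inhibition and lower numbers for stronger inhibition), compound 1 gives > 100000 nM, which is a limit of the assay and not a number. Compound 2 `CCC(C)n1cnc2ncnc(N)c21` gives > 100000 nM, also a limit. Compound 3 `CC(C)Cn1cnc2c(N)ncnc21` gives > 100000 nM, again a limit. The step that the two limits leave unreadable from compound 1 to compound 2 is thus unreadable, since every value shown sits at the limit of > 100000 nM in this assay, at which 3 of the 3 values shown sit. Compound 4 `Nc1ncnc2ncn(CCCO)c12` differs from compound 1 by hydroxy in place of hydrogen on a saturated chain carbon, three bonds along the chain from an aromatic nitrogen. Within the data shown here, no measured step bears on this change; the nearest one, from compound 1 to compound 2, is hidden by the limits. The expected step for compound 4 is therefore a step that the limit leaves unreadable from compound 1 to compound 4 in this assay, meaning nothing readable beyond the scatter. Compound 4 is estimated at 150000 nM, in a range from 30000 nM to 1000000 nM.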

Compound 4, inhibition constant: > 100000 nM
Compound 4: a limit, no number; the forecaster's own chance of this, stated with the estimate: 85%; the middle value does not contradict the limit.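

In this assay compound 4 gives > 100000 nM as a limit, so no step from compound 1 or compound 2 to compound 4 can be read: the limit of > 100000 nM in this assay, at which 4 of the 4 values shown sit.

As far as these compounds go, whether propyl, sec-butyl and 3-hydroxypropyl on the shared core differ at all in this assay stays open.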